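The compounds below may be only part of what the source reports. "The series", "measured", "known", "first", "only" and "open" are said of these compounds alone.

Measured so far in an ADME assay on MCF7 cells (Homo sapiens) for cytotoxicity, with a stated time of 72 h; a lower number here means a stronger inhibitor, a higher number a weaker inhibitor:
compound 1 `COc1cccc(CNc2ncnc3c2ncn3C2CCCO2)c1` gives > 100000 nM.
compound 2 `COc1ccc(CNc2ncnc3c2ncn3C2CCCO2)cc1` gives > 100000 nM.
compound 3 `COc1cc(CNc2ncnc3c2ncn3C2CCCO2)cc(OC)c1` gives > 100000 nM.

For compound 3 this is only a limit of the assay, not a number. For compound 2 the value is likewise only a limit. For compound 1 the value is again only a limit. The cores of compound 1 and compound 2 differ by 4-methoxyphenyl in place of 3-methoxyphenyl on a saturated chain carbon bound to a nitrogen on an aromatic ring; the step between them is a step that the two limits leave unreadable from compound 1 to compound 2. From compound 1 to compound 3 the change is methoxy in place of hydrogen on an aromatic carbon, and the step is a step that the two limits leave unreadable from compound 1 to compound 3. Compound 4 `COc1ccc(CNc2ncnc3c2ncn3C2CCCO2)c(OC)c1` has not yet been measured in this assay. It differs from compound 2 by methoxy in place of hydrogen on an aromatic carbon, the same kind of change as from compound 1 to compound 3, though here the entering methoxy sits ortho to the large group rather than meta to it. Since (the limit of > 100000 nM in this assay, at which 3 of the 3 values shown sit), the earlier step gives no readable size. The step from compound 2 to compound 4 is expected to be a step that the limit leaves unreadable from compound 2 to compound 4. That expectation rests on (the limit of > 100000 nM in this assay, at which 3 of the 3 values shown sit). For compound 4 the estimate is 200000 nM, most probably reported again as a limit only.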

Compound 4, half-maximal inhibitory concentration: > 100000 nM
Compound 4 ended at the assay's limit (the forecaster's own chance of this, stated with the estimate: 85%); the middle value lies beyond the limit too.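

No size can be read for the step between compound 2 and compound 4, as both values are only limits: the limit of > 100000 nM in this assay, at which 4 of the 4 values shown sit.

The compounds shown leave open whether any methoxy pattern on the shared core gives a measurable value.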